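Notes on the phenoxy variant from compound 3 to compound 4

The source may hold more compounds than are shown below. What is called first, only, known or untested is meant among the compounds shown, and "the series" means these compounds.

In an ADME assay on HepG2 cells (Homo sapiens) for cytotoxicity, read by luminescence, CellTiter-Glo and ATP content, with a stated time of 72 h (on this read-out higher numbers stand for an effect only at larger amounts of compound and lower numbers for an effect already at smaller amounts), compound 3 `COc1ccc(F)cc1CNCCCNc1ccnc2cc(Oc3ccc(F)cc3)ccc12` gives 6600 nM, the highest of the three numbers measured. Compound 1 `COc1ccc(F)cc1CNCCCNc1ccnc2cc(Cc3cc(C)cc(C)c3)ccc12` gives 940 nM and compound 2 `COc1ccc(F)cc1CNCCCNc1ccnc2cc(-c3ccc(F)cc3)ccc12` gives 770 nM; a 1.2-fold lower number from compound 1 to compound 2 (0.09 log units; within the scatter) lies within the scatter, whereas a 7.0-fold higher number from compound 1 to compound 3 (0.85 log units; beyond the scatter) and an 8.6-fold higher number from compound 2 to compound 3 (0.93 log units; beyond the scatter) set compound 3 apart from both. Compound 4 `COc1ccc(F)cc1CNCCCNc1ccnc2cc(Oc3ccccc3OC)ccc12` differs from compound 3 as follows: 2-methoxyphenyl in place of 4-fluorophenyl on an oxygen on an aromatic ring. For the measured compounds named here, no measured step touches the substituent on the phenoxy group itself; the two steps into compound 3 concern the link to the shared core, which compound 4 keeps unchanged. The expectation for a 1.1-fold lower number from compound 3 to compound 4 (0.04 log units; within the scatter) is therefore no step beyond the scatter. Compound 4 is estimated at 6000 nM, with a range of 2500 nM to 14000 nM.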

Compound 4, half-maximal effective concentration: 6400 nM
Compound 4: the middle estimate sits 1.1-fold (0.03 log units) below what was measured, within the range that was stated.
By their numbers in this assay, from the lowest: compounds 2 and 1 (each within the scatter of the next); then compounds 4 and 3 (each within the scatter of the next).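

In this assay, 2-methoxyphenyl in place of 4-fluorophenyl on the oxygen stays within the scatter (a 1.0-fold lower number from compound 3 to compound 4 (0.01 log units; within the scatter)), so this change on the phenoxy group leaves the number where it was. The distance from the two compounds without the oxygen link persists (an 8.3-fold higher number from compound 2 to compound 4 (0.92 log units; beyond the scatter); a 6.8-fold higher number from compound 1 to compound 4 (0.83 log units; beyond the scatter)), and among these four compounds both phenoxy variants give the higher numbers, with none going against this. No measurement at hand explains the result.

Still open, as far as these compounds go, is whether an amine or a carboxylic acid on the phenoxy ring would shift the number. From the compounds shown here alone, a longer chain in place of the oxygen link is equally open.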